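Swapping the Arylidene Ring in a Vinyl Sulfone Series

The compounds below may be only part of what the source reports. "The series", "measured", "known", "first", "only" and "open" are said of these compounds alone.

Measured compounds:
- compound 1 `CSc1ccc(/C=C(\C(=O)c2ccc(Cl)cc2)S(=O)(=O)Cc2ccc(Cl)cc2)cc1`: 10000 nM
- compound 2 `CSc1ccc(/C=C(\C(=O)c2ccc(Cl)cc2)S(=O)(=O)Cc2ccc(C)cc2)cc1`: 10000 nM
- compound 3 `Cc1ccc(S(=O)(=O)/C(=C/c2ccc(Cl)cc2)C(=O)c2ccc(Cl)cc2)cc1`: 1000 nM

In a functional assay on DU-145 cells (Homo sapiens) for inhibition, read by trypan blue exclusion, with a stated time of 96 h (a higher number here means a weaker inhibitor of growth, a lower number a stronger inhibitor of growth), compound 1 gives 10000 nM. Compound 2 gives 10000 nM, so the two sit level, and together they are the highest numbers of the three. Compound 3 gives 1000 nM, a clearly lower number than compound 1, but it differs from compound 1 in two places, so nothing single can be drawn from that gap.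

Compound 4 `CCOc1cc(/C=C(\C(=O)c2ccc(Cl)cc2)S(=O)(=O)Cc2ccc(Cl)cc2)ccc1O` has not been measured. It differs from compound 1 in one place: 3-ethoxy-4-hydroxyphenyl in place of 4-(methylsulfanyl)phenyl on a double-bonded chain carbon bound to a double-bonded chain carbon.

Going by the values given here, the only step measured in one place is no change at the digits printed from compound 1 to compound 2 (within the scatter), and it sits elsewhere on the molecule, at a methyl in place of chloro on an aromatic carbon. Among the compounds with values here, no measured step touches the ring that changes here, so there is no direct guide. In this assay compound 4 is therefore expected to stay close to compound 1, with a wide range: 8000 nM (2000 nM to 30000 nM). The expected step is a 1.3-fold lower number from compound 1 to compound 4 (0.10 log units; within the scatter).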

Compound 4, concentration for 50% growth inhibition: 10000 nM
Estimate against measurement, compound 4: 1.3-fold (0.10 log units) below; the measured number falls inside the stated range.
By their numbers in this assay, from the lowest: compound 3; then compounds 1, 2 and 4 (each within the scatter of the next).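

In this assay, putting 3-ethoxy-4-hydroxyphenyl in place of 4-(methylsulfanyl)phenyl gives no change at the digits printed from compound 1 to compound 4 (within the scatter). Going by these compounds alone, this is the first measured change at this position, on a double-bonded chain carbon bound to a double-bonded chain carbon, and it shows that a ring with more heavy atoms and a hydrogen-bond donor leaves the growth-inhibition number where it was, with no gain in strength. Nothing available here explains why the number holds still.

As far as these compounds go, whether an amine or a carboxylic acid on this ring would move the number stays open, as does the effect of a longer chain in place of the ethoxy group. From the compounds shown here alone, it is also open whether 3-ethoxy-4-hydroxyphenyl would give the same result alongside the methyl group of compound 2.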